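Lengthening the Benzamide Linker in a Cyanoguanidine Series

This account rests on a few compounds, and the source may have more. Where it says the series, first, only, none or still open, it means among the compounds named here.

Compound 3 `N#CN/C(=N\CCNC(=O)c1ccccc1)NCCCOc1cccc(CN2CCCCC2)c1` carries a benzamido group on a short chain attached to the shared core. In a functional assay on cardiac atrium for antagonist activity at histamine H2 receptor (Cavia porcellus), tested at 0.3 uM (on this read-out lower numbers stand for lower potency and higher numbers for higher potency (the scale is a negative logarithm)), compound 3 gives 7.82, the highest of the three numbers recorded. Compound 2 `N#CN/C(=N\CCNc1ccc(N=[N+]=[N-])cc1[N+](=O)[O-])NCCCCOc1cccc(CN2CCCCC2)c1` gives 7.47 in this assay, lower by more than the scatter, and compound 1 `N#CN/C(=N\CCCNc1ccc(N=[N+]=[N-])cc1[N+](=O)[O-])NCCCOc1cccc(CN2CCCCC2)c1` gives 6.79, lower still. Neither differs from compound 3 in one place only, so no single step can be read from them. Compound 4 `N#CN/C(=N\CCCNC(=O)c1ccccc1)NCCCOc1cccc(CN2CCCCC2)c1` differs from compound 3 by benzamidomethyl in place of benzamido on a saturated chain carbon, two bonds along the chain from a double-bonded nitrogen. For the measured compounds named here, no measured pair shows the effect of such a chain extension, so the step expected in this assay, a number 0.22 log units lower from compound 3 to compound 4 (within the scatter), is small, within the scatter in either direction. Compound 4 is estimated at 7.6, between 7 and 8.2.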

Compound 4, negative logarithm of the antagonist equilibrium constant: 7.14
The estimate for compound 4 lay 0.46 log units above the measured number; measured number inside the range.
By their numbers in this assay, from the lowest: compound 1; then compound 4; then compound 2; then compound 3.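

In this assay benzamidomethyl in place of benzamido on this saturated chain carbon brings a number 0.68 log units lower from compound 3 to compound 4 (beyond the scatter) and so shows that the chain length at this position affects potency. On the longer chain, benzoyl in place of 4-azido-2-nitrophenyl on the amine nitrogen brings a number 0.35 log units higher from compound 1 to compound 4 (beyond the scatter) and so shows that the group at the chain end also matters. Nothing measured here explains either step. On these data alone, whether 2-benzamidoethyl, a longer chain still, would lower the number further remains open.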